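The source may report more compounds than this note shows. Statements on the series, on what has been measured and on what is new or still open speak of the compounds shown alone.

Compound 1 `COc1ccc(-c2cc(/C=C/C(=O)c3ccc(N)cc3)[nH]n2)cc1`: 94%
Compound 2 `COc1cc(-c2cc(/C=C/C(=O)c3ccc(N)cc3)[nH]n2)cc(OC)c1OC`: 105%

In a functional assay on NCI-H23 cells (Homo sapiens) for cytotoxicity, read by sulforhodamine B assay, with a stated time of 48 h, tested at 0.1 uM (a higher number here means a weaker effect of the compound at the concentration tested, a lower number a stronger effect), compound 2 stands highest of the two numbers measured, and its nearest neighbour is compound 1, whose value lies lower by a margin beyond the usual scatter; compound 1 thus shows the stronger effect of the two at this concentration.

Compound 3 `COc1ccc(-c2cc(/C=C/C(=O)c3ccc(N)cc3)[nH]n2)cc1OC` has not been measured. It differs from compound 2 by hydrogen in place of methoxy on an aromatic carbon. For the measured compounds named here, no step between two measured compounds isolates this change, so its size is unknown from the data. Compound 3 carries fewer methoxy groups than compound 2 and more than compound 1, and its two measured neighbours differ from each other only modestly. The step from compound 2 to compound 3 in this assay is therefore expected to be small and, if anything, downward, at a number 7 percentage points lower from compound 2 to compound 3 (within the scatter). Compound 3 is estimated to give 98% in this assay, within a range from 86% to 110%.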

Compound 3, a percentage reported as activity, at one concentration (the size of the read-out at that concentration, not a potency): 103%
The estimate for compound 3 lay 5 percentage points below the measured number; the measured number falls inside the stated range.
By their numbers in this assay, from the lowest: compounds 1, 3 and 2 (each within the scatter of the next, the first and the last beyond it).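

In this assay, hydrogen in place of methoxy on this aromatic carbon, ortho to a methoxy group and meta to a large group, gives a number 2 percentage points lower from compound 2 to compound 3 (within the scatter), and methoxy in place of hydrogen gives a number 9 percentage points higher from compound 1 to compound 3 (within the scatter). Each single methoxy step thus stays within the scatter, although the two ends of the series, compound 1 and compound 2, lie beyond it, so neither step alone accounts for that gap. No measurement available here gives a reason for these small steps.

From the compounds shown here alone, whether a hydroxyl group, an amine or an ethoxy group on this carbon would move the number beyond the scatter remains open. So does how these compounds would compare at a concentration other than the single one tested.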